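The compounds below may be only part of what the source reports. "The series", "measured", "known", "first", "only" and "open" are said of these compounds alone.

Measured compounds:
- compound 1, `COc1c(C)c(OC)c2c(c1C=O)O[C@H](c1ccccc1)C[C@H]2O`: 99600 nM
- compound 2, `COc1cc(O)c(C=O)c2c1[C@H](OC)C[C@@H](c1ccccc1)O2`: "not active" (no number reported)
- compound 3, `COc1c(C)c(O)c(C=O)c2c1[C@H](O)C[C@@H](c1ccccc1)O2`: 143000 nM

Of the compounds shown here, three have been tested in a functional assay on HepG2 cells (Homo sapiens) for cytotoxicity, read by MTT assay; on this read-out lower numbers stand for stronger inhibition and higher numbers for weaker inhibition. Among the compounds with values here, compound 1 gives 99600 nM and compound 3 gives 143000 nM; the only single-point step among them, a 1.4-fold higher number from compound 1 to compound 3 (0.16 log units; within the scatter), lies within the scatter, so compound 3 and compound 1 cannot be told apart on these numbers. Compound 2 was reported in this assay as "not active" (no number reported) without a number.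

The next compound, compound 4 `COc1c(C)c(O)c(C=O)c2c1[C@H](OC)C[C@@H](c1ccccc1)O2`, departs from compound 3 by one change: methyl in place of hydrogen on an oxygen on a saturated carbon. Within the data shown here, no measured step covers this change, so nothing in the data sets its size or direction. The only related hint is that compound 2 gave no number in this assay, which leaves open that compound 4 could also fall outside the measurable range. Compound 4 is therefore expected to stay close to compound 3, with an estimated step of a 1.3-fold higher number from compound 3 to compound 4 (0.10 log units; within the scatter), and its estimated value is 180000 nM, within a range from 70000 nM to 500000 nM.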

Compound 4, half-maximal inhibitory concentration: 145000 nM
The estimate for compound 4 lay 1.2-fold (0.09 log units) above the measured number, and the stated range covers the measured number.
By their numbers in this assay, from the lowest: compounds 1, 3 and 4 (each within the scatter of the next).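

In this assay, within the data shown here, the change from hydroxy to methoxy on the saturated carbon, read as a 1.0-fold higher number from compound 3 to compound 4 (0.01 log units; within the scatter), lies within the scatter, so this is the only measured step at this place and it separates compound 3 and compound 4 by no readable amount. The methoxy group at this place does not by itself exclude a number: compound 4 gives 145000 nM, while compound 2, which carries the same methoxy group, was reported as "not active" (no number reported). Nothing available explains the result.

From the compounds shown here alone, whether an amine, a carboxylic acid or a longer chain at this place would give a number beyond the scatter remains open. Among these compounds, also open is whether the methyl group on the aromatic ring, the one place where compound 2 and compound 4 differ, decides if a number is obtained at all.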